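Turning the 3-hydroxyphenyl urea back into a longer chain

A few compounds are considered here, and "the series" means these few. Any claim that something is new, unique, unknown or untested is made for them only; others in the source may bear on it.

Measured compounds:
Compound 1 `COc1cc(NC(C)CCCNC(=O)NNC(=O)Nc2ccc(Br)cc2)c2ncccc2c1` gives 110000 nM
Compound 2 `COc1cc(NC(C)CCCNC(=O)Nc2cccc(O)c2)c2ncccc2c1` gives 32000 nM

In a functional assay on CCRF-CEM cells (Homo sapiens) for inhibition, read by MTT assay, with a stated time of 72 h (a lower number here means a stronger inhibitor, a higher number a weaker inhibitor), compound 2 stands at 32000 nM as the lower of the two numbers. Compound 3 `COc1cc(NC(C)CCCNC(=O)NNC(=O)Nc2cccc(F)c2)c2ncccc2c1` carries ((3-fluorophenyl)carbamoyl)amino in place of 3-hydroxyphenyl on an amide-type nitrogen and so resembles compound 1 again. Among the measured compounds shown here, the only measured step bearing on this is a 3.4-fold lower number from compound 1 to compound 2 (0.54 log units; beyond the scatter) with the opposite kind of swap, so a similar step toward a higher number is expected. For the measured compounds named here, no measured step isolates fluorine against bromine on the ring. The estimate is an expected 2.5-fold higher number from compound 2 to compound 3 (0.40 log units; beyond the scatter). Compound 3 is estimated at 80000 nM with a range from 30000 nM to 200000 nM for now.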

Compound 3, half-maximal inhibitory concentration: 98000 nM
Compound 3: the middle estimate sits 1.2-fold (0.09 log units) below what was measured, within the range that was stated.
By their numbers in this assay, from the lowest: compound 2; then compounds 3 and 1 (each within the scatter of the next).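

In this assay, the longer chain gives a 3.1-fold higher number from compound 2 to compound 3 (0.49 log units; beyond the scatter), so the higher number seen with compound 1 returns with a different ring on that chain. Replacing the ring gives a 1.1-fold lower number from compound 1 to compound 3 (0.05 log units; within the scatter), so 3-fluorophenyl and 4-bromophenyl cannot be told apart on this chain. Nothing available here gives a reason for either step.

From the compounds shown here alone, compound 2 differs from compound 3 in both chain and ring substituent, so the share of each in the step remains open. Going by these compounds, how an amine or a carboxylic acid on the ring would read is also open.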